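Putting 1,3-thiazol-2-yl in place of 4-fluorophenyl

This account rests on a few compounds, and the source may have more. Where it says the series, first, only, none or still open, it means among the compounds named here.

In an ADME assay on microsomes from liver (Homo sapiens) for metabolic stability (a higher number here means faster removal of the compound, a lower number slower removal), compound 1 (`C[C@H](NC(=O)Cn1nnc2ccccc2c1=O)c1ccc(F)cc1`) stands at 31 mL/min/kg and compound 2 (`COc1cc(C)ccc1[C@H](C)NC(=O)Cn1nnc2ccccc2c1=O`) at 30 mL/min/kg in the same read-out, two numbers within the scatter of each other. Among the compounds with values here, the two compounds differ in more than one place, so the measurements offer no single-change step to go by. Compound 3 (`C[C@H](NC(=O)Cn1nnc2ccccc2c1=O)c1nccs1`) keeps the core of compound 1 and has 1,3-thiazol-2-yl in place of 4-fluorophenyl on a saturated chain carbon bound to an amide-type nitrogen and a saturated chain carbon. In this assay, within the data shown here, no step clearly beyond the scatter is expected, only a slight lean towards slower removal. The expected move is a 1.3-fold lower number from compound 1 to compound 3 (0.11 log units; within the scatter) on this reading, and it remains uncertain. The estimate for compound 3 is 24 mL/min/kg with a range from 12 mL/min/kg to 45 mL/min/kg in clearance.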

Compound 3, clearance: < 9.9 mL/min/kg
Compound 3 ended at the assay's limit; the forecaster's own chance of this, stated with the estimate: 5%; middle value at least 2.4-fold (0.38 log units) from the limit.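

In this assay, the only step shown at this position is an at least 3.1-fold lower number from compound 1 to compound 3 (0.49 log units; beyond the scatter), and it lies beyond the scatter. It shows that the saturated chain carbon bound to an amide-type nitrogen and a saturated chain carbon is a place where the choice of aromatic ring can change clearance, something compound 1 and compound 2 could not show, as they differ in more than one place. The result for compound 3 is a limit of the assay and not a number, so the full size of the step stays unknown: the limit of < 9.9 mL/min/kg in this assay, at which 1 of the 3 values shown sits.

The compounds shown leave open whether the sulfur or the ring nitrogen of 1,3-thiazol-2-yl matters more. They also leave open whether a 1,3-oxazol-2-yl or pyridin-2-yl group in the same place would give a similar step.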